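Extending a Methyl to Ethyl on the Shared Core

The source may hold more compounds than are shown below. What is called first, only, known or untested is meant among the compounds shown, and "the series" means these compounds.

Compound 1, `C[C@@H]1CCC[C@H](N2CCC(c3cc(Cl)ccc3-n3cc(Cl)nn3)=CC2=O)c2cc(ccn2)-c2c(cnn2C)NC1=O`: 1.08 h
Compound 2, `C[C@@H]1CCC[C@H](N2CCC(c3cc(Cl)ccc3-n3ccnn3)=CC2=O)c2cc(ccn2)-c2c(cnn2C)NC1=O`: 1.13 h

Of the compounds shown here, two have been measured in an ADME assay on microsomes from liver (Homo sapiens) for metabolic stability; a higher number here means that the compound lasts longer, a lower number that the compound disappears faster. Compound 1 `C[C@@H]1CCC[C@H](N2CCC(c3cc(Cl)ccc3-n3cc(Cl)nn3)=CC2=O)c2cc(ccn2)-c2c(cnn2C)NC1=O` gives 1.08 h. Compound 2 `C[C@@H]1CCC[C@H](N2CCC(c3cc(Cl)ccc3-n3ccnn3)=CC2=O)c2cc(ccn2)-c2c(cnn2C)NC1=O` gives 1.13 h, and its value and that of compound 1 lie within the scatter of each other, so the two cannot be told apart on this measurement. Among the compounds with values here, the one measured step, a 1.0-fold higher number from compound 1 to compound 2 (0.02 log units; within the scatter), swaps a chloro on an aromatic carbon for hydrogen and moves the half-life by nothing beyond the scatter.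

Compound 3 `CCn1ncc2c1-c1ccnc(c1)[C@@H](N1CCC(c3cc(Cl)ccc3-n3ccnn3)=CC1=O)CCC[C@@H](C)C(=O)N2` differs from compound 2 by methyl in place of hydrogen on a saturated chain carbon bound to an aromatic nitrogen; cut one bond further out, the change reads methyl to ethyl. Within the data shown here, no measured step touches this part of the shared core, and the only step available concerns a different group, so there is nothing in the numbers to point up or down. For compound 3 the expected step is a 1.1-fold lower number from compound 2 to compound 3 (0.05 log units; within the scatter), a change within the scatter. Compound 3 is estimated at 1 h, with a range from 0.5 h to 2.2 h.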

Compound 3, half-life: 0.167 h
Compound 3: middle estimate off by 6.0-fold (0.78 log units), on the high side; the whole stated range lies above it.
By their numbers in this assay, from the lowest: compound 3; then compounds 1 and 2 (each within the scatter of the next).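

In this assay, within the data shown here, replacing methyl with ethyl on the shared core gives a 6.8-fold lower number from compound 2 to compound 3 (0.83 log units; beyond the scatter), the first evidence that the half-life responds to a change at this position. One added carbon, placed on a saturated chain carbon bound to an aromatic nitrogen, is enough to carry the result beyond the scatter, whereas the swap of chloro for hydrogen elsewhere in the molecule, a 1.0-fold higher number from compound 1 to compound 2 (0.02 log units; within the scatter), stayed within it. The data at hand offer no measured explanation for the drop in half-life, so the result records its size but not its cause.

With only methyl and ethyl shown here, a single step cannot tell whether the half-life would keep falling as the chain grows, so a longer chain such as propyl remains an open case, as does a small ring such as cyclopropyl in the same place. It is also open whether the same step would have a similar size with the chloro group of compound 1 in the molecule, since that pairing does not appear among these compounds.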